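Replacing Carboxy with Hydroxymethyl in an Angiotensin Ligand Series

A few compounds are considered here, and "the series" means these few. Any claim that something is new, unique, unknown or untested is made for them only; others in the source may bear on it.

Compound 2 `CCCCCN(CCCCC)C(=O)N1CCN(C(=O)N(c2ccccc2)c2ccccc2)[C@H](C(=O)O)C1` was tested in an assay for inhibition of Type-2 angiotensin II receptor (Rattus norvegicus) (a lower number here means a stronger inhibitor, a higher number a weaker inhibitor), where compound 2 gives 1.4 nM. Compound 1 `CCCCCN(CCCCC)C(=O)N1CCN(C(=O)N(c2ccccc2)c2ccccc2)C(C(=O)O)C1` has the same atoms and bonds and gives 1.7 nM; the step of a 1.2-fold lower number from compound 1 to compound 2 (0.08 log units; within the scatter) lies within the scatter, which fits with the fact that one of compounds 1 and 2 is drawn with a defined configuration and the other without, at the place where they differ. Compound 3 `CN(C(=O)N1CCN(C(=O)N(c2ccccc2)c2ccccc2)[C@H](C(=O)O)C1)c1ccccc1` gives 170 nM, and the step of a 120-fold higher number from compound 2 to compound 3 (2.08 log units; beyond the scatter) is large. Among the three, compound 2 is therefore indistinguishable from compound 1 and well separated from compound 3.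

Compound 4 `CCCCCN(CCCCC)C(=O)N1CCN(C(=O)N(c2ccccc2)c2ccccc2)[C@H](CO)C1` differs from compound 2 in a single place: hydroxymethyl in place of carboxy on a saturated ring carbon. Neither measured step bears directly on this change, since one concerns only how a stereocentre is drawn and the other the exchange of dipentylamino for methyl(phenyl)amino. The measured compounds thus give no calibration for removing the carboxy, and the estimate must stay wide. Compound 4 is expected to give a higher number, with an estimated step of a 57-fold higher number from compound 2 to compound 4 (1.76 log units; beyond the scatter), so that compound 4 is estimated at 80 nM, in a range from 8 nM to 800 nM.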

Compound 4, half-maximal inhibitory concentration: 30 nM
Compound 4: middle estimate off by 2.7-fold (0.43 log units), on the high side; the measured number falls inside the stated range.
By their numbers in this assay, from the lowest: compounds 2 and 1 (each within the scatter of the next); then compound 4; then compound 3.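

In this assay the exchange of carboxy for hydroxymethyl on this saturated ring carbon gives a 21-fold higher number from compound 2 to compound 4 (1.33 log units; beyond the scatter) and is the first step shown at this position that lies beyond the scatter, as the earlier step here concerned only how the stereocentre is drawn. The carboxy is therefore not required for inhibition in this series, although its loss weakens it: compound 4 still gives 30 nM in this assay without that group. Nothing known here accounts for the size of this step.

On these data alone, whether a methyl ester, a primary amide or a tetrazole at this place would give a number nearer that of compound 2 or compound 4 remains open. So does whether the hydroxymethyl exchange has a step of similar size with methyl(phenyl)amino in place of dipentylamino.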